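Lengthening One Arm of a Symmetric Keto Diacid

The source may hold more compounds than are shown below. What is called first, only, known or untested is meant among the compounds shown, and "the series" means these compounds.

Compound 1 `CC(C)(CCCCC(=O)CCCCC(C)(C)C(=O)O)C(=O)O` is a ketone carrying a carboxylic acid at each end of its chain. In a functional assay on cells (Hepatocyte, Rattus norvegicus) for inhibition (a higher number here means a weaker inhibitor, a lower number a stronger inhibitor), compound 1 gives 3000 nM, the second highest of the three numbers measured. Its nearest neighbour is the diol compound 2 `CC(C)(CO)CCCCCCC(=O)CCCCCCC(C)(C)CO`, which gives 2000 nM; these two numbers lie within the scatter of each other. Furthest away is compound 3 `CC(C)(CCCCC(=O)CCCC(C)(C)C(=O)O)C(=O)O`, which gives 8000 nM; the step of a 2.7-fold higher number from compound 1 to compound 3 (0.43 log units; beyond the scatter) follows from removing one chain carbon on one arm.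

Compound 4 `CC(C)(CCCCCC(=O)CCCCC(C)(C)C(=O)O)C(=O)O` goes the other way from compound 1: 2-carboxy-2-methylpropyl in place of 1-carboxy-1-methylethyl on a saturated chain carbon, four bonds along the chain from a carbonyl carbon. Among the compounds with values here, the only measured step that bears on this change is the one from compound 1 to compound 3, a modest rise on shortening an arm. Within the data shown here, whether adding a chain carbon reverses that trend or merely extends it cannot be read from compound 3 alone, and compound 2, the only compound with longer arms, has different end groups. A small step in this assay is therefore expected, in either direction, likely not far beyond the scatter. Compound 4 is estimated at 3500 nM, within 1500 nM to 9000 nM, an expected step of a 1.2-fold higher number from compound 1 to compound 4 (0.07 log units; within the scatter).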

Compound 4, half-maximal inhibitory concentration: 3000 nM
Compound 4: middle estimate off by 1.2-fold (0.07 log units), on the high side, and the stated range covers the measured number.
By their numbers in this assay, from the lowest: compounds 2, 1 and 4 (each within the scatter of the next); then compound 3.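

In this assay, 2-carboxy-2-methylpropyl in place of 1-carboxy-1-methylethyl on a saturated chain carbon, four bonds along the chain from a carbonyl carbon, gives no change at the digits printed from compound 1 to compound 4 (within the scatter), so this arm of the keto diacid accepts the larger group without a measurable shift in the number. Set beside a 2.7-fold higher number from compound 1 to compound 3 (0.43 log units; beyond the scatter), which lies beyond the scatter, the new step shows that among these three diacids the response to arm length is not the same in both directions: the shorter arm of compound 3 raises the number, while the longer arm of compound 4 leaves it where compound 1 stands. No measurement shown here explains this difference between shortening and lengthening the arm.

Still open, as far as these compounds go, is whether a longer chain on this arm would continue to leave the number unchanged, or whether lengthening both arms of the diacid together would lower it. From the compounds shown here alone, compound 2 differs from compound 1 in more than one place, so the effect of its longer arms cannot be separated from that of its end groups, and how an amide at the chain end would compare with the carboxylic acid also remains unknown.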